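Benzyl removal on the aryl ketone of the boronic chalcone series

The compounds below may be only part of what the source reports. "The series", "measured", "known", "first", "only" and "open" are said of these compounds alone.

Two members of the series have been run in a functional assay on SK-OV-3 cells (Homo sapiens) for cytotoxicity, read by MTT assay, with a stated time of 48 h; a lower number here means a stronger inhibitor, a higher number a weaker inhibitor. Compound 1 `O=C(/C=C/c1ccc2c(c1)B(O)OC2)c1cccnc1` gives 18500 nM there. Compound 2 `O=C(/C=C/c1ccc2c(c1)B(O)OC2)c1ccc(OCc2ccccc2)cc1` gives 6000 nM in this assay, which is the lower of the two numbers; against compound 1 the gap lies beyond the usual scatter. Compound 3 `O=C(/C=C/c1ccc2c(c1)B(O)OC2)c1ccc(O)cc1` is the next member, not yet measured. It differs from compound 2 by hydrogen in place of benzyl on an oxygen on an aromatic ring, so that the benzyloxy of compound 2 becomes a hydroxy in compound 3. Within the data shown here, no measured pair shows this change, so its effect is not known from the numbers in hand. The expectation is a moderate weakening, with compound 3 landing nearer to compound 1 than to compound 2, estimated as a 2.0-fold higher number from compound 2 to compound 3 (0.30 log units; within the scatter). For compound 3 the estimate in this assay is 12000 nM, with a range from 4000 nM to 40000 nM.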

Compound 3, half-maximal inhibitory concentration: 13000 nM
Compound 3: the middle estimate sits 1.1-fold (0.03 log units) below what was measured, within the range that was stated.
By their numbers in this assay, from the lowest: compound 2; then compounds 3 and 1 (each within the scatter of the next).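

In this assay, among these compounds, the change from benzyloxy to hydroxy gives a 2.2-fold higher number from compound 2 to compound 3 (0.34 log units; beyond the scatter), the first direct reading of this position, and it registers as a modest step. The change to 4-hydroxyphenyl in place of pyridin-3-yl on a carbonyl carbon gives a 1.4-fold lower number from compound 1 to compound 3 (0.15 log units; within the scatter), so these two groups are not told apart in this assay. Nothing on hand bears on why either step has its size.

Open, on these data alone, is how much of the step belongs to the benzyl ring and how much to the chain on the oxygen: a methyl or a longer alkyl chain on that oxygen would separate the two. Also open, as far as these compounds go, is whether an amine or a carboxylic acid in place of the benzyloxy would keep the number of compound 2 or move it further.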